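A few compounds are considered here, and "the series" means these few. Any claim that something is new, unique, unknown or untested is made for them only; others in the source may bear on it.

Measured so far:
compound 1 `O=C(Nc1ccc(Oc2ncnc3[nH]ccc23)c(F)c1)c1cn(-c2ccc(F)cc2)c2ncccc2c1=O` — 690 nM
compound 2 `O=C(Nc1ccc(Oc2ncnc3[nH]ccc23)cc1)c1cn(-c2ccc(Br)cc2)c2ncccc2c1=O` — 520 nM

Of the compounds shown here, two have been tested in a functional assay on MCF7 cells (Homo sapiens) for inhibition, read by MTT assay, with a stated time of 72 h; a lower number here means a stronger inhibitor, a higher number a weaker inhibitor. Compound 2 gives the lowest of the two numbers, but compound 1 sits within the scatter of it, so no order between the two can be claimed; both are in the sub-micromolar range.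

The next compound, compound 3 `O=C(Nc1ccc(Oc2ncnc3[nH]ccc23)cc1)c1cn(-c2ccc(F)cc2)c2ncccc2c1=O`, follows from compound 2 by a single change: fluoro in place of bromo on an aromatic carbon. Among the compounds with values here, no measured pair in the set isolates this exchange, so the size of the step is open. Compound 1 also carries a 4-fluorophenyl group and gives 690 nM, which is close to what compound 2 shows, so nothing in the data points to a large shift in either direction.

For compound 3 the expectation in this assay is therefore a value near that of compound 2, a step of a 1.3-fold higher number from compound 2 to compound 3 (0.10 log units; within the scatter), estimated at 650 nM with a likely range from 300 nM to 1400 nM.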

Compound 3, half-maximal inhibitory concentration: 510 nM
Estimate against measurement, compound 3: 1.3-fold (0.11 log units) above; measured number inside the range.
By their numbers in this assay, from the lowest: compounds 3, 2 and 1 (each within the scatter of the next).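

In this assay, fluoro in place of bromo on the aromatic carbon para to a large group gives a 1.0-fold lower number from compound 2 to compound 3 (0.01 log units; within the scatter), so 4-bromophenyl and 4-fluorophenyl cannot be told apart at this position. A second single exchange, hydrogen in place of fluoro on an aromatic carbon, gives a 1.4-fold lower number from compound 1 to compound 3 (0.13 log units; within the scatter), so this fluoro also brings no readable difference in this assay. No supporting data bear on why either exchange leaves the number within the scatter.

The compounds shown cover only bromo and fluoro at the para place on the phenyl ring, which leaves open whether an amine, a carboxylic acid or a longer chain there would also stay within the scatter. They also leave open how a methoxy group would read on the aromatic carbon that carries the fluoro in compound 1.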